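Swapping a Methyl for Methylpiperazine on a Shared Core

The source may report more compounds than this note shows. Statements on the series, on what has been measured and on what is new or still open speak of the compounds shown alone.

Compound 3 `Cc1ccc2[nH]c(=O)nc(-c3ccccc3)c2c1` is one of three compounds examined in an ADME assay on THP-1 cells (Homo sapiens) for cytotoxicity, read by MTT assay, with a stated time of 72 h; on this read-out lower numbers stand for an effect already at smaller amounts and higher numbers for an effect only at larger amounts of compound. In this assay compound 3 gives only a limit, > 50000 nM. Compound 1 `O=c1nc(-c2ccccc2)c2cc(-c3ccc(F)cc3)ccc2[nH]1` likewise reaches only a limit, > 50000 nM. Compound 2 `O=c1nc(-c2ccccc2)c2cc(-c3cn[nH]c3)ccc2[nH]1` also gives a limit, > 50000 nM. Because all three sit at the limit of > 50000 nM in this assay, at which 3 of the 3 values shown sit, the steps a step that the two limits leave unreadable from compound 1 to compound 2, a step that the two limits leave unreadable from compound 1 to compound 3 and a step that the two limits leave unreadable from compound 2 to compound 3 cannot be read in size. Compound 4 `CN1CCN(c2ccc3[nH]c(=O)nc(-c4ccccc4)c3c2)CC1` carries 4-methylpiperazin-1-yl in place of methyl on an aromatic carbon. Within the data shown here, no measured step therefore tells how large this change should be on the read-out; the only guide is that every compound so far lies at the limit. Compound 4 is expected to show a number no higher from compound 3 to compound 4 (the limit leaves the size open). The estimated value of compound 4 is 50000 nM, with a range from 15000 nM to 100000 nM.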

Compound 4, half-maximal effective concentration: > 50000 nM
Compound 4 gave a limit, no number (the forecaster's own chance of this, stated with the estimate: 75%); the middle value lies on the limit itself.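

In this assay, among these compounds, compound 4 gives a limit, as do compound 1, compound 2 and compound 3, so no step to compound 4 can be read in size: the limit of > 50000 nM in this assay, at which 4 of the 4 values shown sit. The compounds shown leave open whether swapping these groups changes the read-out at all.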